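This account rests on a few compounds, and the source may have more. Where it says the series, first, only, none or still open, it means among the compounds named here.

Measured so far:
compound 1 `CCCc1ncc2c(C)nnc(O)n12` — > 48000 nM
compound 2 `C=CCn1ncc2cncn2c1=O` — > 48000 nM
compound 3 `CCCc1nc(C)c2c(C)nnc(O)n12` — 14000 nM

In a functional assay for inhibition, with Homo sapiens as the target (a higher number here means a weaker inhibitor, a lower number a stronger inhibitor), compound 1 gives only a limit, > 48000 nM. Compound 2 likewise gives only a limit, > 48000 nM. Compound 3 gives 14000 nM in this assay. The change from compound 1 to compound 3 is methyl in place of hydrogen on an aromatic carbon, and it gives an at least 3.4-fold lower number from compound 1 to compound 3 (0.53 log units; beyond the scatter), a size that rests on (the limit of > 48000 nM in this assay, at which 2 of the 3 values shown sit).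

The difference between the two cores of compound 1 and compound 2 is not broken down here. Compound 4 `C=CCn1ncc2cnc(C)n2c1=O` carries the same kind of change on the core of compound 2: methyl in place of hydrogen on an aromatic carbon. The surroundings are not the same: in compound 3 the methyl sits next to the ring nitrogen, two ring bonds from the ring nitrogen and two ring bonds from the ring atom that bears a propyl group, whereas in compound 4 it sits between two ring nitrogen atoms. The step from compound 2 to compound 4 is expected to be an at least 1.6-fold lower number from compound 2 to compound 4 (0.20 log units; that floor lies within the scatter). That expectation rests on compound 2 giving only a limit, > 48000 nM. It rests too on an at least 3.4-fold lower number from compound 1 to compound 3 (0.53 log units; beyond the scatter), the same kind of change at a different place. Compound 4 is estimated at 30000 nM in this assay, roughly 9000 nM to 90000 nM.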

Compound 4, half-maximal inhibitory concentration: > 48000 nM
Compound 4 gave a limit, no number (the forecaster's own chance of this, stated with the estimate: 55%); middle value at least 1.6-fold (0.20 log units) away from the limit.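

In this assay compound 4 gives only a limit, > 48000 nM. Among these compounds, compound 2 is also a limit, so no step from it to compound 4 can be read. As far as these compounds go, whether methyl changes the number on this core stays open.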